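The source may hold more compounds than are shown below. What is called first, only, known or untested is meant among the compounds shown, and "the series" means these compounds.

Measured compounds in the series:

compound 1 `CCOC(=O)c1c(NC(C)c2ccccc2)[nH]c2ccc(O)cc12` — 4600 nM
compound 2 `CCOC(=O)c1c(NC(C)c2ccccc2)[nH]c2ccccc12` — 5900 nM

Within the data shown here, compound 1 stands at the lowest of the two numbers in an assay on isolated protein for inhibition of Polyunsaturated fatty acid 5-lipoxygenase (Homo sapiens) (a higher number here means a weaker inhibitor, a lower number a stronger inhibitor), but its only neighbour is compound 2, and a 1.3-fold higher number from compound 1 to compound 2 (0.11 log units; within the scatter) lies within the scatter, so the two cannot be ordered; hydrogen in place of hydroxy on an aromatic carbon leaves this assay unchanged as far as these two compounds show.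

Compound 3 `CC(Nc1[nH]c2ccc(O)cc2c1C#N)c1ccccc1` is the next point. It differs from compound 1 by cyano in place of ethoxycarbonyl on an aromatic carbon. Among the measured compounds shown here, no measured step touches this group: the one step available, from compound 1 to compound 2, concerns the hydroxy and says nothing about exchanging the ethoxycarbonyl for a cyano. The expectation for compound 3 therefore rests on compound 1 alone, with a wide allowance in either direction. The estimate for compound 3 is 6000 nM, with a range from 1500 nM to 25000 nM; this means an expected step of a 1.3-fold higher number from compound 1 to compound 3 (0.12 log units; within the scatter), not beyond the scatter as a central guess, though a shift either way would not be surprising.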

Compound 3, half-maximal inhibitory concentration: 4100 nM
For compound 3 the middle estimate is 1.5-fold (0.17 log units) above the measured one, and the stated range covers the measured number.
By their numbers in this assay, from the lowest: compounds 3, 1 and 2 (each within the scatter of the next).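

In this assay, cyano can stand in place of ethoxycarbonyl on this aromatic carbon of the five-membered ring, two ring bonds from the ring nitrogen, with a 1.1-fold lower number from compound 1 to compound 3 (0.05 log units; within the scatter). The two compounds therefore cannot be told apart here, although the entering group has 2 heavy atoms against 5 for the group that leaves, has 1 hydrogen-bond acceptor against 2, and carries a triple bond in place of a double bond. At this position, then, the full ethoxycarbonyl is not needed to reach the level seen with compound 1, a point the earlier hydroxy step could not address. No measured evidence bears on why these two groups read alike.

As far as these compounds go, it remains open whether a carboxylic acid, a primary amide or an amine on this carbon would stay within the scatter of compound 3 in this assay or move clearly away from it. Also open, from the compounds shown here alone, is whether the cyano group reads the same once the hydroxy is replaced by hydrogen, and whether any group here can bring the series to clearly lower numbers.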